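The source may hold more compounds than are shown below. What is called first, only, known or untested is meant among the compounds shown, and "the series" means these compounds.

Measured compounds:
compound 1 `COc1ccc2c(=O)c(/C=C/C(=O)NCc3ccccc3)coc2c1`; in a functional assay on HeLa cells (Homo sapiens) for inhibition, read by MTT assay, with a stated time of 48 h (a higher number here means a weaker inhibitor, a lower number a stronger inhibitor), compound 1 gives 33400 nM
compound 2 `COc1ccc2c(=O)c(/C=C/C(=O)NCc3cccc(F)c3)coc2c1`; in this assay compound 2 gives 17600 nM
compound 3 `COc1ccc2c(=O)c(/C=C/C(=O)NCc3ccc(F)cc3)coc2c1`; in this assay compound 3 gives > 100000 nM

The value of compound 3 is a limit of the assay and not a number, so compound 3 is placed only by the steps that lead to it: an at least 2.9-fold higher number from compound 1 to compound 3 (0.47 log units; beyond the scatter) and an at least 5.6-fold higher number from compound 2 to compound 3 (0.75 log units; beyond the scatter). Among the measured compounds shown here, it is the one value among the three that sits at the limit of > 100000 nM in this assay, at which 1 of the 3 values shown sits. Between the other two, a 1.9-fold lower number from compound 1 to compound 2 (0.28 log units; within the scatter), so their numbers are not ordered.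

Compound 4 `COc1ccc(CNC(=O)/C=C/c2coc3cc(OC)ccc3c2=O)cc1` differs from compound 3 by methoxy in place of fluoro on an aromatic carbon. For the measured compounds named here, no measured step exchanges a fluoro for a methoxy; the only steps that touch this aromatic carbon are those that put fluoro there, from compound 1 to compound 3 and from compound 2 to compound 3, both beyond the scatter and both raising the number. Whether a methoxy at the same place behaves like the fluoro is not shown by the three compounds.

With compound 3 at a limit, the direction of the step can only be downward or none. Compound 4 is expected near the number of compound 1, 33400 nM, with wide uncertainty, so the step is estimated as an at least 2.0-fold lower number from compound 3 to compound 4 (0.30 log units; that floor lies within the scatter). Compound 4 is estimated at 50000 nM, between 15000 nM and 150000 nM.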

Compound 4, half-maximal inhibitory concentration: > 100000 nM
Compound 4: only a limit was reported; the forecaster's own chance of this, stated with the estimate: 35%; at least 2.0-fold (0.30 log units) between middle value and limit.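

In this assay, methoxy on the aromatic carbon para to a large group gives an at least 2.9-fold higher number from compound 1 to compound 4 (0.47 log units; beyond the scatter), and the change from 3-fluorophenyl to 4-methoxyphenyl gives an at least 5.6-fold higher number from compound 2 to compound 4 (0.75 log units; beyond the scatter). The raised number at this position is therefore no longer tied to fluoro alone, since a second group, with more heavy atoms and a hydrogen-bond acceptor, also moves the compound beyond the scatter relative to compound 1 and compound 2. The values of compound 3 and compound 4 are both limits of the assay and not numbers, so the step between them cannot be read and fluoro and methoxy stay unordered here, while compound 2, with fluoro on a different ring carbon, stands against any reading that every substitution on this ring raises the number: the limit of > 100000 nM in this assay, at which 2 of the 4 values shown sit.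

Still open, going by these compounds, is whether any group at this position keeps a readable number, for example an amine, a carboxylic acid or a methyl group. Also open, on these data alone, is whether methoxy on the ring carbon that carries fluoro in compound 2 would stay close to compound 1 or reach the limit.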